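The source may hold more compounds than are shown below. What is called first, only, known or untested is meant among the compounds shown, and "the series" means these compounds.

Measured in a functional assay on HT-29 cells (Homo sapiens) for inhibition, read by luminescence and CellTiter-Glo, with a stated time of 24 h; a higher number here means that more compound is needed for the effect, a lower number that less compound is needed:

- compound 1 `CN1C(=S)[C@@H](NC(=O)c2nc(Cc3ccccc3)n(C3CCCCCC3)n2)COc2ccccc21`: 5530 nM
- compound 2 `CN1C(=S)[C@@H](NC(=O)c2nc(Cc3ccccc3)n(-c3ncccn3)n2)COc2ccccc21`: 3970 nM

These two compounds share the same core and differ only in the group on an aromatic nitrogen, where pyrimidin-2-yl in compound 2 takes the place of cycloheptyl in compound 1. For the measured compounds named here, compound 2 therefore stands within the scatter of compound 1, the only other compound measured so far, and the two cannot be told apart on these numbers.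

The next compound, compound 3 `Cc1cnc(-n2nc(C(=O)N[C@H]3COc4ccccc4N(C)C3=S)nc2Cc2ccccc2)nc1`, keeps this framework but turns pyrimidin-2-yl into 5-methylpyrimidin-2-yl: methyl in place of hydrogen on an aromatic carbon. In words, this is methyl in place of hydrogen on an aromatic carbon, para to a large group.

Going by the values given here, no measured step tests a methyl group directly. The closest evidence is a 1.4-fold lower number from compound 1 to compound 2 (0.14 log units; within the scatter), an exchange of the whole group on that nitrogen that left the number within the scatter. A single added methyl is a smaller change, so the expected outcome is a 1.0-fold lower number from compound 2 to compound 3 (0.02 log units; within the scatter), which would be no step beyond the scatter. In this assay, compound 3 is estimated at 3800 nM, with an expected range of 1900 nM to 7500 nM.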

Compound 3, half-maximal effective concentration: 1950 nM
The estimate for compound 3 lay 1.9-fold (0.29 log units) above the measured number; the measured number falls inside the stated range.
By their numbers in this assay, from the lowest: compound 3; then compounds 2 and 1 (each within the scatter of the next).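

In this assay, the group on this nitrogen had so far shown no clear effect, since exchanging cycloheptyl for pyrimidin-2-yl gave a 1.4-fold lower number from compound 1 to compound 2 (0.14 log units; within the scatter) and stayed within the scatter. Yet one methyl on an aromatic carbon, para to a large group, gives a 2.0-fold lower number from compound 2 to compound 3 (0.31 log units; beyond the scatter) and so shows that this position on the pyrimidine can move the number, if only modestly, and the same group also separates from the cycloheptyl of compound 1, with a 2.8-fold lower number from compound 1 to compound 3 (0.45 log units; beyond the scatter) as the step. No measurement shown here accounts for this gain, so it stands as an observation without a known cause.

As far as these compounds go, a single methyl is only one point at this carbon, so it remains open whether the number would keep falling with a longer chain such as ethyl, or would respond differently to a methoxy group, a chlorine atom or an amine. From the compounds shown here alone, it is also open whether the same methyl would have a similar effect with other groups at the remaining positions of the shared core.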